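Swapping the nitro-bearing ring for a chlorine-bearing one

The compounds below may be only part of what the source reports. "The series", "measured", "known", "first", "only" and "open" are said of these compounds alone.

Of the compounds shown here, three built on one shared core have been tested in a functional assay on MIA PaCa-2 cells (Homo sapiens) for cytotoxicity, read by MTT assay, with a stated time of 72 h; on this read-out higher numbers stand for an effect only at larger amounts of compound and lower numbers for an effect already at smaller amounts. Compound 1 `O=C1/C(=C\c2c(Cl)cccc2Cl)c2ccccc2N1c1c(Cl)cccc1Cl` gives only a limit of the assay, > 100 ug/mL. Compound 2 `COc1ccc(/C=C2\C(=O)N(c3c(Cl)cccc3Cl)c3ccccc32)cc1` likewise gives only a limit, > 100 ug/mL. Compound 3 `O=C1/C(=C\c2ccccc2[N+](=O)[O-])c2ccccc2N1c1c(Cl)cccc1Cl` is the only one of the three that gives a real number, 5 ug/mL, while the other two sit at the limit of > 100 ug/mL in this assay, at which 2 of the 3 values shown sit. The step that the two limits leave unreadable from compound 1 to compound 2 cannot be read, but an at least 20-fold lower number from compound 1 to compound 3 (1.30 log units; beyond the scatter) and an at least 20-fold lower number from compound 2 to compound 3 (1.30 log units; beyond the scatter) both show the 2-nitrophenyl version standing far apart from its two neighbours.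

Compound 4 `O=C1/C(=C\c2ccc(Cl)cc2)c2ccccc2N1c1c(Cl)cccc1Cl` now reverses that move: 4-chlorophenyl in place of 2-nitrophenyl on a double-bonded chain carbon bound to a double-bonded ring carbon. Among the compounds with values here, the 2-nitrophenyl that set compound 3 apart is gone, and a halogen-bearing ring related to the one on compound 1 takes its place. Within the data shown here, since the only two readable steps were large and both ran towards the 2-nitrophenyl compound, the expectation for compound 4 is a step of similar size in the opposite direction, an 8.0-fold higher number from compound 3 to compound 4 (0.90 log units; beyond the scatter), with a real chance that it ends at the assay limit. The estimate for compound 4 in this assay is therefore 40 ug/mL, within a range from 8 ug/mL to 150 ug/mL.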

Compound 4, concentration for half-maximal effect: 5 ug/mL
Compound 4: the middle estimate sits 8.0-fold (0.90 log units) above what was measured; the whole stated range lies above it.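

In this assay, the nitro group proves not to be required at this position: putting 4-chlorophenyl in place of 2-nitrophenyl gives no change at the digits printed from compound 3 to compound 4 (within the scatter), even though the entering group has no hydrogen-bond acceptors and the leaving group has two. A chlorine-bearing ring is also not enough to lose the effect, since the ring's exact chlorine pattern separates two close relatives, with 4-chlorophenyl in place of 2,6-dichlorophenyl giving an at least 20-fold lower number from compound 1 to compound 4 (1.30 log units; beyond the scatter). A change of one group on the ring has an equally clear outcome, with chloro in place of methoxy giving an at least 20-fold lower number from compound 2 to compound 4 (1.30 log units; beyond the scatter), so two quite different rings now share a low number while the other two compounds stay at the assay's limit: the limit of > 100 ug/mL in this assay, at which 2 of the 4 values shown sit.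

The compounds shown leave open whether 2-chlorophenyl or 4-nitrophenyl would behave like compound 3 and compound 4, which would help separate the effect of the group from that of its place on the ring. From the compounds shown here alone, it also remains open whether a ring bearing an amine or a carboxylic acid at this same place would keep the number low.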